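Replacing the aryl group of compound 3 with oxan-4-yl

A few compounds are considered here, and "the series" means these few. Any claim that something is new, unique, unknown or untested is made for them only; others in the source may bear on it.

Measured in a toxicity assay on HeLa cells (Homo sapiens) for cytotoxicity; a lower number here means that less compound is tolerated, a higher number that more compound is tolerated:
Compound 1 `COc1nc(-c2ccc(Br)cc2)ccc1[C@@H](c1ccccc1)[C@@](O)(CCN(C)C)c1cccc2ccccc12`: > 64 ug/mL (a limit)
Compound 2 `COc1ncc(-c2ccccc2)cc1[C@@H](c1ccccc1)[C@@](O)(CCN(C)C)c1ccccc1`: 11.9 ug/mL
Compound 3 `COc1nc(-c2ccc(C(F)(F)F)cc2)ccc1[C@@H](c1ccccc1)[C@@](O)(CCN(C)C)c1cccc2ccccc12`: > 64 ug/mL (a limit)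

Compound 3 stands at > 64 ug/mL, which is a limit and not a number. It shares that position with compound 1, as the limit of > 64 ug/mL in this assay, at which 2 of the 3 values shown sit, shows. Among the measured compounds shown here, the one measured step is a step that the two limits leave unreadable from compound 1 to compound 3, so it offers no size to carry forward.

Compound 4 `COc1nc(C2CCOCC2)ccc1[C@@H](c1ccccc1)[C@@](O)(CCN(C)C)c1cccc2ccccc12` puts oxan-4-yl in place of 4-(trifluoromethyl)phenyl on an aromatic carbon, next to the ring nitrogen: oxan-4-yl in place of 4-(trifluoromethyl)phenyl on an aromatic carbon. For the measured compounds named here, no measured step bears directly on this change. The only true number in this assay belongs to compound 2, at 11.9 ug/mL, which shows that a measurable reading can occur among these compounds.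

A modest step toward less compound tolerated is therefore expected, only tentatively, as an at least 1.6-fold lower number from compound 3 to compound 4 (0.20 log units; that floor lies within the scatter). For compound 4 the estimate is 40 ug/mL, with an expected range from 14 ug/mL to 100 ug/mL.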

Compound 4, half-maximal cytotoxic concentration: 22.5 ug/mL
The estimate for compound 4 lay 1.8-fold (0.25 log units) above the measured number; the measured number falls inside the stated range.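

In this assay, this position now yields readable steps: oxan-4-yl in place of 4-(trifluoromethyl)phenyl gives an at least 2.8-fold lower number from compound 3 to compound 4 (0.45 log units; beyond the scatter), and oxan-4-yl in place of 4-bromophenyl gives an at least 2.8-fold lower number from compound 1 to compound 4 (0.45 log units; beyond the scatter). Both lie beyond the scatter, so this position, on an aromatic carbon next to the ring nitrogen, responds to the exchange of an aryl group for oxan-4-yl, whereas the exchange of bromo for trifluoromethyl could not be read. Both sizes are only floors, since the two aryl compounds sit at one shared limit: the limit of > 64 ug/mL in this assay, at which 2 of the 4 values shown sit.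

The compounds shown leave open whether the lower number goes with the loss of the aromatic ring or with the entry of the ring oxygen, as the two change together. A cyclohexyl group or a piperidin-4-yl amine at this position would bear on that question.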